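Thiophene in Place of Phenyl on a Receptor Agonist

A few compounds are considered here, and "the series" means these few. Any claim that something is new, unique, unknown or untested is made for them only; others in the source may bear on it.

In a functional assay on CHO cells for agonist activity at Free fatty acid receptor 1 (Homo sapiens), read by FLIPR and calcium flux, tested at 100 nM (on this read-out lower numbers stand for a weaker effect and higher numbers for a stronger effect at the one concentration tested), compound 1 `O=C(O)CC1COc2cc(OCc3nnc(-c4ccccc4)s3)ccc21` gives 3.36%. Compound 2 `Cc1nc(-c2ccccc2)sc1COc1ccc2c(c1)OCC2CC(=O)O` gives 54.8% in this assay, the higher of the two numbers, and its gap to compound 1 lies beyond the usual scatter. Compound 3 `Cc1nc(-c2cccs2)sc1COc1ccc2c(c1)OCC2CC(=O)O` has not yet been measured; it differs from compound 2 in one place: thiophen-2-yl in place of phenyl on an aromatic carbon. Within the data shown here, no measured pair shows this exact change, so the expected step is a modest loss that may stay within the scatter, a number 9.8 percentage points lower from compound 2 to compound 3 (within the scatter). Compound 3 is expected to give about 45% in this assay, with a likely range from 20% to 70%.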

Compound 3, a percentage reported as activity, at one concentration (the size of the read-out at that concentration, not a potency): 35.2%
Compound 3: the middle estimate sits 9.8 percentage points above what was measured; low and high end bracket the measured number.
By their numbers in this assay, from the lowest: compound 1; then compound 3; then compound 2.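

At this aromatic carbon, next to the ring nitrogen and the ring sulfur, thiophen-2-yl in place of phenyl gives a number 19.6 percentage points lower from compound 2 to compound 3 (beyond the scatter) in this assay. This pair shows that the position is sensitive to which aromatic ring it carries, yet the phenyl can be exchanged without losing the whole effect at the one concentration tested. Nothing available here explains the drop. Going by these compounds, whether pyridin-2-yl, thiophen-3-yl or a saturated cyclohexyl ring would match phenyl remains open. So does whether this change would act the same way on the core of compound 1.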